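From 4-cyanobenzyl to 3-cyanobenzyl in compound 4

The source may hold more compounds than are shown below. What is called first, only, known or untested is meant among the compounds shown, and "the series" means these compounds.

Measured so far in a functional assay on a cell-free system (plasma, Oryctolagus cuniculus) for inhibition, with stated times of 5 min, 1 min and 6 min; on this read-out higher numbers stand for weaker inhibition and lower numbers for stronger inhibition:
- Compound 1 `CCOC(=O)c1c(C)nc(-c2cccc(C#N)c2)n1OC(C)C`: 6740 nM
- Compound 2 `CCOC(=O)c1c(C)nc(-c2cccc(C#N)c2)n1OCc1ccc(F)cc1`: 5880 nM
- Compound 3 `CCOC(=O)c1c(C)nc(-c2cccc(C#N)c2)n1OCc1ccc(C#N)cc1`: 4240 nM

These three compounds share a core and differ only in the group on one oxygen. Compound 3 is not clearly set apart from the other two, since neither of its steps exceeds the usual scatter between repeat measurements.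

Compound 4 `CCOC(=O)c1c(C)nc(-c2cccc(C#N)c2)n1OCc1cccc(C#N)c1` has the same atoms as compound 3, joined differently: 3-cyanophenyl in place of 4-cyanophenyl on a saturated chain carbon bound to an oxygen on an aromatic ring. In words, 3-cyanophenyl stands in place of 4-cyanophenyl on a saturated chain carbon bound to an oxygen on an aromatic ring.

Among the compounds with values here, three measured steps bear on this place. Replacing isopropyl gave a 1.1-fold lower number from compound 1 to compound 2 (0.06 log units; within the scatter) and a 1.6-fold lower number from compound 1 to compound 3 (0.20 log units; within the scatter), while cyano in place of fluoro gave a 1.4-fold lower number from compound 2 to compound 3 (0.14 log units; within the scatter). Within the data shown here, no measured pair shows a group moved around a ring, so this remains an extrapolation. With all three steps inside the scatter, no real shift in either direction is expected in this assay.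

The expected change is a 1.1-fold higher number from compound 3 to compound 4 (0.04 log units; within the scatter). For compound 4 the estimated value is 4600 nM, with an expected range of 2400 nM to 8800 nM.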

Compound 4, half-maximal inhibitory concentration: > 30000 nM
Compound 4: a limit, no number; the forecaster's own chance of this, stated with the estimate: 3%; middle value at least 6.5-fold (0.81 log units) from the limit.
By their numbers in this assay, from the lowest: compounds 3, 2 and 1 (each within the scatter of the next). At a limit, above all of these: compound 4.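

Compound 4 gives no number in this assay, only a limit: the limit of > 30000 nM in this assay, at which 1 of the 4 values shown sits.

Moving the nitrile, so that 3-cyanophenyl stands in place of 4-cyanophenyl with no atom gained or lost, gives an at least 7.0-fold higher number from compound 3 to compound 4 (0.84 log units; beyond the scatter), which shows that this position responds to where the nitrile sits on the ring, something the earlier compounds, all within the scatter of each other, could not show. As far as these compounds go, the other two steps point the same way, at an at least 5.1-fold higher number from compound 2 to compound 4 (0.70 log units; beyond the scatter) and an at least 4.4-fold higher number from compound 1 to compound 4 (0.64 log units; beyond the scatter), so 3-cyanobenzyl also stands apart from 4-fluorobenzyl and isopropyl, although the true size of all three steps stays unknown at a limit.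

Still open, from the compounds shown here alone, is whether an amine or a carboxylic acid in place of the nitrile on the 3-cyanobenzyl group would behave like compound 4 or like compound 3. The compounds shown also do not tell why moving the nitrile matters.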